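Compound 2 to compound 3: a new group on the carbonyl carbon

This account rests on a few compounds, and the source may have more. Where it says the series, first, only, none or still open, it means among the compounds named here.

- compound 1 `Fc1ccc(Nc2cc3[nH]c(Nc4cc(N5CCNCC5)ccn4)nc3cn2)cc1C(F)(F)F`: 31000 nM
- compound 2 `O=C(c1ccnc(Nc2nc3cnc(Nc4ccc(F)c(C(F)(F)F)c4)cc3[nH]2)c1)N1CCN(C2CC2)CC1`: 30000 nM

Both numbers come from an ADME assay on CHO cells (Cricetulus griseus) for cytotoxicity, read by MTT assay (on this read-out higher numbers stand for lower toxicity in this test and lower numbers for higher toxicity in this test), and are the only two measured so far. Compound 2 stands level with compound 1, with no meaningful gap between them. Going by the values given here, the one measured step is a 1.0-fold lower number from compound 1 to compound 2 (0.01 log units; within the scatter) and it lies within the scatter. In that step, a (4-cyclopropylpiperazin-1-yl)carbonyl group took the place of a piperazin-1-yl group on an aromatic carbon.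

Compound 3 `C[C@@H]1CN(C(=O)c2ccnc(Nc3nc4cnc(Nc5ccc(F)c(C(F)(F)F)c5)cc4[nH]3)c2)C[C@H](C)N1` keeps the shared core and differs from compound 2 in one place: 3,5-dimethylpiperazin-1-yl in place of 4-cyclopropylpiperazin-1-yl on a carbonyl carbon. Among the compounds with values here, no measured compound carries the 3,5-dimethylpiperazin-1-yl group, so the data offer only indirect guidance. Within the data shown here, the sole guide is the step at this same part of the molecule, a 1.0-fold lower number from compound 1 to compound 2 (0.01 log units; within the scatter), which left the number within the scatter. On that basis, no change beyond the scatter is expected in this assay for this smaller swap. The expected move is a 1.2-fold lower number from compound 2 to compound 3 (0.08 log units; within the scatter) and this is only an estimate. For compound 3 the estimated value is 25000 nM as the middle figure. The expected range for compound 3 runs from 10000 nM to 60000 nM in this estimate.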

Compound 3, half-maximal cytotoxic concentration: 29000 nM
For compound 3 the middle estimate is 1.2-fold (0.06 log units) below the measured one, within the range that was stated.
By their numbers in this assay, from the lowest: compounds 3, 2 and 1 (each within the scatter of the next).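

In this assay the swap of 4-cyclopropylpiperazin-1-yl for 3,5-dimethylpiperazin-1-yl on the carbonyl carbon gives a 1.0-fold lower number from compound 2 to compound 3 (0.01 log units; within the scatter) and so shows that this position can take a second, differently built ring without a shift beyond the scatter. That holds even though the entering group has lost the three-membered ring, carries a hydrogen-bond donor that the leaving group lacks and has two defined stereocentres. The longer comparison, a 1.1-fold lower number from compound 1 to compound 3 (0.03 log units; within the scatter), also stays within the scatter, so all three compounds now sit level in this assay, while nothing available explains why these different groups give such similar numbers.

As far as these compounds go, all three groups compared here are piperazine rings, so it remains open whether a carboxylic acid or a morpholin-4-yl group on the carbonyl carbon would also leave the number within the scatter. The compounds shown also leave open whether another stereochemical arrangement of the two methyl groups would give a similar number.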